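Chain extension on the selenocyanate arm of compound 2

A few compounds are considered here, and "the series" means these few. Any claim that something is new, unique, unknown or untested is made for them only; others in the source may bear on it.

In a functional assay on LoVo cells (Homo sapiens) for inhibition, read by MTT assay, with a stated time of 48 h (on this read-out lower numbers stand for stronger inhibition and higher numbers for weaker inhibition), compound 2 `COc1ccc(N(C)c2nc(C)nc3ccccc23)cc1OCCCCC[Se]C#N` gives 5210 nM, the highest number among the three measured compounds. Compound 3 `Cc1nc(N(C)c2ccc([Se]C#N)c(F)c2)c2ccccc2n1` gives 13 nM and compound 1 `C[Se]c1ccc(N(C)c2nc(C)nc3ccccc23)cc1C` gives 9 nM; both stand beyond the scatter from compound 2, while against each other they fall within it, so no order is drawn between compound 1 and compound 3. Compound 4 `COc1ccc(N(C)c2nc(C)nc3ccccc23)cc1OCCCCCC[Se]C#N` has not yet been measured in this assay. It differs from compound 2 in one place: a group of 4 heavy atoms (2 carbon, 1 nitrogen, 1 selenium; no ring) in place of a group of 3 heavy atoms (1 carbon, 1 nitrogen, 1 selenium; no ring), on a saturated chain carbon, five bonds along the chain from an oxygen on an aromatic ring. Within the data shown here, no measured pair shows this kind of step, and no other chain length is available for comparison; the change lengthens the chain while the selenium-bearing end stays in place. For that reason the step in this assay is expected to be small, none beyond the scatter, with no direction favoured. Compound 4 is therefore estimated at 5000 nM, with a range of 2000 nM to 12500 nM. This corresponds to an expected step of a 1.0-fold lower number from compound 2 to compound 4 (0.02 log units; within the scatter).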

Compound 4, half-maximal inhibitory concentration: 8580 nM
Compound 4: middle estimate off by 1.7-fold (0.23 log units), on the low side; measured number inside the range.
By their numbers in this assay, from the lowest: compounds 1 and 3 (each within the scatter of the next); then compounds 2 and 4 (each within the scatter of the next).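

In this assay, the first step read at this place, on a saturated chain carbon, five bonds along the chain from an oxygen on an aromatic ring, is a 1.6-fold higher number from compound 2 to compound 4 (0.22 log units; within the scatter). Putting the group of 4 heavy atoms in place of the group of 3 heavy atoms therefore leaves the number unchanged within the scatter, and compound 2 and compound 4 form a single level, so this one lengthening gives no sign that chain length matters here. No supporting data bear on this result, and the step carries no explanation.

Going by these compounds, one step cannot show whether the number stays level across other chain lengths, so a shorter chain or a longer chain remains open. Also open, on these data alone, is how a carboxylic acid or an amine in place of the selenium-bearing group would read.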